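Aroyl ring exchange on the low-reading compound 1

The compounds below may be only part of what the source reports. "The series", "measured", "known", "first", "only" and "open" are said of these compounds alone.

Compound 1 `O=C(/C=C/c1ccc(/C=N/NC(=O)c2ccncc2)cc1)c1cccc(Br)c1` sits at the bottom of the three measured numbers: in a functional assay on the whole organism (Ear) for inhibition, with Mus musculus as the target, with a stated time of 30 min, at a dose of 100 mg/kg by the intraperitoneal route (on this read-out higher numbers stand for more inhibition at the one dose given (going by the name of the read-out) and lower numbers for less inhibition), compound 1 gives 14%, below both companions by steps beyond the scatter. Compound 2 `N=C(N)N/N=C/c1ccc(/C=C/C(=O)c2cccc(Br)c2)cc1` gives 49.7% in this assay, and the step of a number 35.7 percentage points higher from compound 1 to compound 2 (beyond the scatter) is the one large movement seen so far. Compound 3 `N=C(N)N/N=C/c1ccc(/C=C/C(=O)c2ccc(Cl)cc2)cc1` gives 56.4% in this assay; the step of a number 6.7 percentage points higher from compound 2 to compound 3 (within the scatter) stays within the scatter.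

Compound 4 `O=C(N/N=C/c1ccc(/C=C/C(=O)c2ccc(Cl)cc2Cl)cc1)c1ccncc1` keeps the shared core of compound 1 and is altered at a single place: 2,4-dichlorophenyl in place of 3-bromophenyl on a carbonyl carbon. Among the measured compounds shown here, the one measured step touching the same carbonyl-bound ring is a number 6.7 percentage points higher from compound 2 to compound 3 (within the scatter), a halogen-ring swap that did not move the read-out beyond the scatter, although it was made on the companion group of compound 2 rather than that of compound 1. The large step of a number 35.7 percentage points higher from compound 1 to compound 2 (beyond the scatter) concerns the other end of the molecule and does not bear on this change. For the measured compounds named here, no measured pair tests a 2,4-dichlorophenyl. The expected outcome for compound 4 is therefore a step of a number 4 percentage points higher from compound 1 to compound 4 (within the scatter), not beyond the scatter. Compound 4 is estimated at 18%, with a range from 5% to 34%.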

Compound 4, a percentage reported as inhibition, in the whole organism at one dose (the size of the read-out at that dose, not a potency): 83.8%
Compound 4: middle estimate off by 65.8 percentage points, on the low side; measured number above the stated range.
By their numbers in this assay, from the lowest: compound 1; then compounds 2 and 3 (each within the scatter of the next); then compound 4.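

Notes on the carbonyl-bound ring: in this assay, 2,4-dichlorophenyl in place of 3-bromophenyl on a carbonyl carbon gives a number 69.8 percentage points higher from compound 1 to compound 4 (beyond the scatter), so this position can move the read-out by a large amount, whereas the only earlier change here, a number 6.7 percentage points higher from compound 2 to compound 3 (within the scatter), stayed within the scatter on a different amine-nitrogen group. The amine-nitrogen group of compound 1 is also retained in compound 4, which gives 83.8%, so that group does not by itself hold the read-out low. Nothing available accounts for the size of this step.

The ring of compound 4 and the ring of compound 3 appear only with different amine-nitrogen groups, so the shown compounds cannot say whether the gain from the 2,4-dichlorophenyl ring carries over to the amine-nitrogen group of compound 2. From the compounds shown here alone, how much of the gain depends on the halogens on this ring also remains open, and an unsubstituted phenyl or a methoxyphenyl on the same carbonyl carbon would bear on that question.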